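From acetyl to methoxycarbonyl on the shared core

The source may hold more compounds than are shown below. What is called first, only, known or untested is meant among the compounds shown, and "the series" means these compounds.

Measured in a functional assay on the whole organism for antagonist activity, with Mus musculus as the target; on this read-out lower numbers stand for an effect already at smaller amounts and higher numbers for an effect only at larger amounts of compound:
Compound 1 `CC(=O)N(C)C(C)C#CCn1ccnc1`: > 100 mg/kg (a limit, not a number)
Compound 2 `CC(=O)NCC#CCn1ccnc1`: > 100 mg/kg (a limit, not a number)
Compound 3 `CC(=O)NCC#CCn1cncc1C`: 66 mg/kg

In this assay, among the compounds with values here, compound 3 holds the only actual number of the series, 66 mg/kg. Compound 1 and compound 2 both stand at the limit of > 100 mg/kg in this assay, at which 2 of the 3 values shown sit.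

The next compound to be measured is compound 4 `COC(=O)NCC#CCn1cncc1C`. Its difference from compound 3 is methoxy in place of methyl on a carbonyl carbon. In words, this is methoxy in place of methyl on a carbonyl carbon, which turns acetamido into (methoxycarbonyl)amino.

Within the data shown here, only one measured step exists, an at least 1.5-fold lower number from compound 2 to compound 3 (0.18 log units; that floor lies within the scatter). That step is methyl in place of hydrogen on an aromatic carbon, so it is a different change at a different place and bears on this one only loosely. Among the measured compounds shown here, no measured compound shows what a change on the carbonyl carbon does. No step beyond the scatter is therefore expected in either direction, and the expectation rests on compound 3 with its 66 mg/kg. The expected step is no change at the digits printed from compound 3 to compound 4 (within the scatter). A result at the limit would also fit this expectation. For compound 4 the estimated value is 66 mg/kg, with an expected range from 28 mg/kg to 150 mg/kg.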

Compound 4, dose for half-maximal effect: 66 mg/kg
Compound 4: middle estimate and measured number agree at the digits printed; low and high end bracket the measured number.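

In this assay, within the data shown here, the change on the carbonyl carbon gives no change at the digits printed from compound 3 to compound 4 (within the scatter), the first reading of any change at this place. Methoxy, with 2 heavy atoms and 1 hydrogen-bond acceptor, enters where methyl, with 1 heavy atom and 0 hydrogen-bond acceptors, leaves, and acetamido and (methoxycarbonyl)amino cannot be told apart on this read-out, so compound 4 joins compound 3 as a second actual number on the methyl-bearing core. Compound 1 and compound 2 stay at a limit, not a number: the limit of > 100 mg/kg in this assay, at which 2 of the 4 values shown sit.

The compounds shown do not tell whether this result holds for other groups on the carbonyl carbon, such as a longer chain like ethoxy or an amine like dimethylamino, since one exchange at this place says nothing about what a larger or different group would do. They also leave open whether (methoxycarbonyl)amino would behave in the same way on the core of compound 2, which lacks the methyl on the aromatic carbon, and whether any group at this place can move the number beyond the scatter.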